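Working notes: amine-bearing side group swap on the shared core

The source may report more compounds than this note shows. Statements on the series, on what has been measured and on what is new or still open speak of the compounds shown alone.

Measured so far:
compound 1 `Cc1cc(Cl)cc(-c2ccnc3cc(CN4C(=O)C5C(C4=O)C5(C)C)sc23)c1NC1CCCNC1` — 33 nM
compound 2 `Cc1cc(Cl)cc(-c2ccnc3cc(CN4C(=O)CCC4=O)sc23)c1CN1[C@@H](C)CNC[C@@H]1C` — 60 nM

In an assay on RKO cells for inhibition of ubiquitin carboxyl-terminal hydrolase 7 (Homo sapiens), read by a luciferase reporter, with a stated time of 18 h (a higher number here means that more compound is needed for the effect, a lower number that less compound is needed), compound 1 gives 33 nM and compound 2 gives 60 nM; the two numbers sit within the usual scatter of each other, so neither is set apart. Among the measured compounds shown here, compound 2 thus stands level with compound 1 on this assay, and no single-point step between them has been worked out.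

Compound 3 `Cc1cc(Cl)cc(-c2ccnc3cc(CN4C(=O)CCC4=O)sc23)c1O[C@@H]1CCNC[C@@H]1C` has not yet been measured. It differs from compound 2 by (3-methylpiperidin-4-yl)oxy in place of (2,6-dimethylpiperazin-1-yl)methyl on an aromatic carbon; the basic ring nitrogen and one hydrogen-bond donor are kept. For the measured compounds named here, the series gives no measured step for such a change, so no direction is supported and nothing beyond the scatter is expected. The estimate for compound 3 is 60 nM (range 20 nM to 200 nM), an expected step of no change at the digits printed from compound 2 to compound 3 (within the scatter).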

Compound 3, half-maximal effective concentration: 150 nM
For compound 3 the middle estimate is 2.5-fold (0.40 log units) below the measured one; low and high end bracket the measured number.
By their numbers in this assay, from the lowest: compounds 1 and 2 (each within the scatter of the next); then compound 3.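

In this assay, among the compounds shown here, (3-methylpiperidin-4-yl)oxy in place of (2,6-dimethylpiperazin-1-yl)methyl gives a 2.5-fold higher number from compound 2 to compound 3 (0.40 log units; beyond the scatter), the only step so far and one that lies beyond the scatter. This aromatic carbon, ortho to a large group and to a methyl group and para to a chloro group, therefore does respond to a change of side group, although the leaving and entering groups have the same counts of hydrogen-bond donors and acceptors and no net charge. Nothing measured here ties the step to a property of either group.

Which part of the change carries the step stays open, as the ring and the atom joining it to the core change together. A (3-methylpiperidin-4-yl)methyl group, which would place the ring of compound 3 on the carbon link of compound 2, could separate the two.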